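A few compounds are considered here, and "the series" means these few. Any claim that something is new, unique, unknown or untested is made for them only; others in the source may bear on it.

Compound 1 `CCOc1cc(NC(=O)C2(NC(=O)c3ccc4c(C5CCCC5)c(-c5ncc(Cl)cn5)n(C)c4c3)CCC2)ccc1/C=C/C(=O)OCC(Cl)(Cl)Cl` gives, in an ADME assay (liver) for pharmacokinetics, with Liver microsome (Homo sapiens) as the target, using microsomes (a lower number here means that the compound disappears faster, a higher number that the compound lasts longer), a value of > 5 h, which is a limit of the assay.
Compound 2 `CCOc1cc(NC(=O)C2(NC(=O)c3ccc4c(C5CCCC5)c(-c5ncc(Cl)cn5)n(C)c4c3)CCC2)ccc1/C=C/C(=O)OCc1ccccc1` gives in this assay a value of > 5 h, again a limit of the assay.

Compound 2 therefore stands at the limit of > 5 h in this assay, at which 2 of the 2 values shown sit, so its true half-life is not known, only that it reached the end of the measurement window. For the measured compounds named here, the single step between the two measured compounds, a step that the two limits leave unreadable from compound 1 to compound 2, cannot be read for size, since both ends are limits.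

Compound 3 `CCCN(C)C(=O)COC(=O)/C=C/c1ccc(NC(=O)C2(NC(=O)c3ccc4c(C5CCCC5)c(-c5ncc(Cl)cn5)n(C)c4c3)CCC2)cc1OCC` differs from compound 2 by a single change: methyl(propyl)carbamoyl in place of phenyl on a saturated chain carbon bound to an oxygen next to a carbonyl group. The only measured step that bears on this change is a step that the two limits leave unreadable from compound 1 to compound 2, and it tells nothing about size or direction, so no change beyond the usual scatter can be predicted from the numbers shown.

On that basis compound 3 is expected to give about 4 h in this assay, with a likely range from 1.5 h to 8 h. This estimate corresponds to a step of an at least 1.2-fold lower number from compound 2 to compound 3 (0.09 log units; that floor lies within the scatter), with a fair chance that the assay again reports only a limit.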

Compound 3, half-life: 0.317 h
Compound 3: middle estimate off by 13-fold (1.10 log units), on the high side; the measured number lies below the stated range.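

At a saturated chain carbon bound to an oxygen next to a carbonyl group, the choice of group proves to matter in this assay: methyl(propyl)carbamoyl in place of phenyl gives an at least 15-fold lower number from compound 2 to compound 3 (1.19 log units; beyond the scatter), and methyl(propyl)carbamoyl in place of trichloromethyl gives an at least 15-fold lower number from compound 1 to compound 3 (1.19 log units; beyond the scatter). The earlier pair could not show this sensitivity, and the step between compound 1 and compound 2 cannot be read, since both of their values are limits: the limit of > 5 h in this assay, at which 2 of the 3 values shown sit. Among the three compounds, then, phenyl and trichloromethyl both stay at that limit, while methyl(propyl)carbamoyl brings the half-life into the measurable range, and the true size of both new steps remains tied to limits rather than to exact numbers.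

As far as these compounds go, it remains open which part of methyl(propyl)carbamoyl goes with the shorter half-life, and whether a dimethylcarbamoyl group, a plain propyl chain or a carboxylic acid at this place would behave like it or like phenyl. From the compounds shown here alone, what happens chemically to compound 3 in this assay also stays open, as the half-life alone does not identify any product or the part of the molecule that changes.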